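A halogen swap on a compound already past the assay limit

The source may hold more compounds than are shown below. What is called first, only, known or untested is meant among the compounds shown, and "the series" means these compounds.

The three measured compounds were all tested in a functional assay on U-87MG ATCC cells for antiproliferative activity against U-87 MG (Homo sapiens), read by MTT assay, with a stated time of 72 h; on this read-out lower numbers stand for stronger inhibition and higher numbers for weaker inhibition:

- compound 1, `Cc1nn(C)c(Oc2cccc(F)c2)c1/C=N\CCCCCOc1cc2oc(=O)cc(C)c2cc1Cl`, gives 9870 nM
- compound 2, `Cc1ccc(Oc2c(/C=N\CCCCCOc3cc4oc(=O)cc(C)c4cc3Cl)c(C)nn2C)cc1`, gives 7970 nM
- compound 3, `Cc1nn(C)c(Oc2cccc(F)c2)c1/C=N\CCCCCCOc1cc2oc(=O)cc(C)c2cc1Cl`, gives > 25000 nM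

The value for compound 3 is a limit of this assay, not a number, so compound 3 stands at the limit of > 25000 nM in this assay, at which 1 of the 3 values shown sits, and all that is known is that it is a weak inhibitor. Compound 4, `Cc1nn(C)c(Oc2ccc(Br)cc2)c1/C=N\CCCCCCOc1cc2oc(=O)cc(C)c2cc1Cl`, differs from compound 3 only in the aryl ether: 4-bromophenyl in place of 3-fluorophenyl on an oxygen on an aromatic ring.

For the measured compounds named here, only one measured step changes that same aryl group, and it is a 1.2-fold lower number from compound 1 to compound 2 (0.09 log units; within the scatter). On that basis a change of the aryl group on the oxygen is expected to move the number little, if at all, and compound 3 already sits at a limit. Compound 4 is therefore expected to remain at or near that limit, with a step that the limit leaves unreadable from compound 3 to compound 4. The estimate for compound 4 is 30000 nM, within a range from 10000 nM to 90000 nM.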

Compound 4, half-maximal inhibitory concentration: 5420 nM
For compound 4 the middle estimate is 5.5-fold (0.74 log units) above the measured one, and the stated range ends above it.
By their numbers in this assay, from the lowest: compounds 4, 2 and 1 (each within the scatter of the next). At a limit, above all of these: compound 3.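

The aryl group on the oxygen is not a silent position: in this assay, 4-bromophenyl in place of 3-fluorophenyl gives an at least 4.6-fold lower number from compound 3 to compound 4 (0.66 log units; beyond the scatter), a step beyond the usual scatter. For the compounds shown here, the only earlier change at this place, a 1.2-fold lower number from compound 1 to compound 2 (0.09 log units; within the scatter), stayed within the scatter, so the group swapped in can matter here, though not every swap does. The value of compound 3 is a limit and not a number, so the true size of the new step stays unknown: the limit of > 25000 nM in this assay, at which 1 of the 4 values shown sits.

The two steps differ in the group that enters and in the rest of the molecule, so they do not show whether 4-bromophenyl would act the same way on compound 1. Nor do they separate the bromine from its place on the ring, which 3-bromophenyl or 4-fluorophenyl on the same oxygen could address.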